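A few compounds are considered here, and "the series" means these few. Any claim that something is new, unique, unknown or untested is made for them only; others in the source may bear on it.

In an ADME assay on microsomes from liver (Homo sapiens) for metabolic stability, read by LC-MS, with a stated time of 30 min, tested at 1 uM (on this read-out lower numbers stand for a less stable compound and higher numbers for a more stable compound), the compounds read as follows:
Compound 1 `O=C(NCc1ccc(S(=O)(=O)c2ccccc2)cc1)c1nc2cnccc2[nH]1` gives 73%
Compound 2 `O=C(NCc1ccc(S(=O)(=O)c2ccccc2)cc1)c1c[nH]c2ccncc12` gives > 99%
Compound 3 `O=C(NCc1ccc(S(=O)(=O)c2cccc(C(F)(F)F)c2)cc1)c1cnc2nccn2c1` gives 41%

The entry for compound 2 (> 99%) is a limit of the assay and not a number. Compound 3 stands lowest on these numbers, and compound 1, the nearest, reads higher by more than the scatter.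

Compound 4 `O=C(NCc1ccc(S(=O)(=O)c2ccccc2)cc1)c1cnc2nccn2c1` keeps the core of compound 3 and carries hydrogen in place of trifluoromethyl on an aromatic carbon, so that 3-(trifluoromethyl)phenyl becomes phenyl. Going by the values given here, no measured step touches this place. The only one, a number at least 26 percentage points higher from compound 1 to compound 2 (beyond the scatter), changes the group on a carbonyl carbon, so it shows how far one change can move this assay but gives no direct size for this one. The sole further hint is that compound 1, which carries phenyl on a different core, gives 73% in this read-out. A small rise is therefore expected, an estimated a number 9 percentage points higher from compound 3 to compound 4 (within the scatter) that is not expected to stand clearly beyond the scatter. The estimate for compound 4 is 50% as the expected value, with the expected range running from 25% to 80% as the likely bounds.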

Compound 4, percent of the compound remaining: 60%
The estimate for compound 4 lay 10 percentage points below the measured number; the measured number falls inside the stated range.
By their numbers in this assay, from the lowest: compound 3; then compound 4; then compound 1. At a limit, above all of these: compound 2.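

Going by these compounds alone, with the core held the same, a number 19 percentage points higher from compound 3 to compound 4 (beyond the scatter), so in this assay the change from 3-(trifluoromethyl)phenyl to phenyl gives the first direct reading at this place, and it lies beyond the scatter. With phenyl now shared by compound 1, compound 2 and compound 4, the group on the carbonyl carbon can also be compared on a common background: a number 13 percentage points lower from compound 1 to compound 4 (beyond the scatter), and a number at least 39 percentage points lower from compound 2 to compound 4 (beyond the scatter). The second of these steps has only one open end, as the reading for compound 2 is a limit and not a number: the limit of > 99% in this assay, at which 1 of the 4 values shown sits.

The compounds shown carry 3-(trifluoromethyl)phenyl on the core of compound 3 alone, so they leave open whether the same exchange would move the read-out by a similar amount on the core of compound 1 or the core of compound 2. They also leave open how other groups on that aromatic carbon, such as a chlorine atom, a methoxy group, a nitrile or an amine, would read against hydrogen and trifluoromethyl in this assay.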